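The compounds below may be only part of what the source reports. "The series", "measured", "known", "first", "only" and "open" are said of these compounds alone.

Measured so far:
compound 1 `COc1cccc(C(C)Sc2nc3c(cnn3C)c(=O)n2-c2ccccc2)c1` — 451 nM
compound 2 `CC(Oc1nc2c(cnn2C)c(=O)n1-c1ccccc1)c1ccccc1` — 2400 nM

In an assay on isolated protein for inhibition of aldehyde dehydrogenase 1A1 (Homo sapiens) (on this read-out lower numbers stand for stronger inhibition and higher numbers for weaker inhibition), compound 1 gives 451 nM, the lower of the two numbers; compound 2 gives 2400 nM, a gap beyond the usual scatter. Compound 3 `CC(Sc1nc2c(cnn2C)c(=O)n1-c1ccccc1)c1ccccc1` is not yet measured. It differs from compound 1 by hydrogen in place of methoxy on an aromatic carbon. For the measured compounds named here, no step of this kind between measured compounds exists, so the size of the step is open; a modest weakening, near the edge of the scatter, is expected for the step of a 1.8-fold higher number from compound 1 to compound 3 (0.25 log units; within the scatter). For compound 3 the estimate in this assay is 800 nM, with a range from 300 nM to 2500 nM.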

Compound 3, half-maximal inhibitory concentration: 130 nM
For compound 3 the middle estimate is 6.2-fold (0.79 log units) above the measured one; measured number outside the range, below it.
By their numbers in this assay, from the lowest: compound 3; then compound 1; then compound 2.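

In this assay the change from 3-methoxyphenyl to phenyl gives a 3.5-fold lower number from compound 1 to compound 3 (0.54 log units; beyond the scatter) and so counts as a gain beyond the scatter. On this core, methoxy at this aromatic carbon is not needed for the lower number, and the unsubstituted phenyl reads better than the methoxy compound. No measurement on hand gives a cause for the step. Still open, from the compounds shown here alone, is whether only hydrogen serves here, or whether a smaller group such as fluorine or methyl on the same carbon matches compound 3. A single pair also leaves unclear whether a hydroxyl or an amine at this place would behave like methoxy.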